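Ring-closing the propyl on the imidazole nitrogen

This account rests on a few compounds, and the source may have more. Where it says the series, first, only, none or still open, it means among the compounds named here.

Measured compounds:
- compound 1, `COc1ccc(Br)cc1CCc1c(Cl)cccc1-c1nccn1C(C)C`: 1400 nM
- compound 2, `CCCn1ccnc1-c1cccc(Cl)c1CCc1cc(Br)ccc1OC`: 1900 nM

Compound 2 has the highest of the two numbers in a functional assay on HEK293 cells (Homo sapiens), read by cAMP accumulation (a lower number here means a stronger inhibitor, a higher number a weaker inhibitor), with compound 1 nearest at a 1.4-fold higher number from compound 1 to compound 2 (0.13 log units; within the scatter), so the two compounds cannot be told apart on this assay.

Compound 3, `COc1ccc(Br)cc1CCc1c(Cl)cccc1-c1ncc2n1CCCC2`, is not yet measured. It differs from compound 2 by a group of 9 heavy atoms (7 carbon, 2 nitrogen; one five-membered aromatic ring with 2 hetero atoms, one six-membered non-aromatic ring with 1 hetero atom) in place of a group of 8 heavy atoms (6 carbon, 2 nitrogen; one five-membered aromatic ring with 2 hetero atoms), on an aromatic carbon. In effect the propyl chain of compound 2 is tied back onto the five-membered aromatic ring so that a six-membered non-aromatic ring is formed.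

For the measured compounds named here, only one measured step exists, a 1.4-fold higher number from compound 1 to compound 2 (0.13 log units; within the scatter), and it swaps one small alkyl group on the aromatic nitrogen for another without a change beyond the scatter. It suggests that this part of the molecule tolerates small changes, but it says nothing direct about closing a ring. The expected step is therefore a 1.1-fold lower number from compound 2 to compound 3 (0.02 log units; within the scatter), that is, no change beyond the scatter, with a wide range to cover the untested ring closure.

Compound 3 is expected to give 1800 nM in this assay, within a range from 600 nM to 5500 nM.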

Compound 3, half-maximal inhibitory concentration: 590 nM
Compound 3: middle estimate off by 3.1-fold (0.48 log units), on the high side; the whole stated range lies above it.
By their numbers in this assay, from the lowest: compound 3; then compounds 1 and 2 (each within the scatter of the next).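

In this assay, tying the propyl chain back onto the five-membered aromatic ring gives a 3.2-fold lower number from compound 2 to compound 3 (0.51 log units; beyond the scatter), and setting the same ring system against the isopropyl compound gives a 2.4-fold lower number from compound 1 to compound 3 (0.38 log units; beyond the scatter), so compound 3 is the strongest inhibitor of the three. The earlier swap of isopropyl for propyl on the aromatic nitrogen moved the number by no more than the scatter, so that step made this position look indifferent to change, whereas the ring closure shows that the number can move here beyond the scatter, though only modestly. No measurement among these compounds accounts for the difference, so the data show that the number moved and not why it moved.

The new group also holds one more carbon than the 1-propyl-1H-imidazol-2-yl group it replaces, so an open butyl chain on the same nitrogen would be needed to separate the effect of the ring from that of the added atom. Also open, as far as these compounds go, is how far the gain extends, for instance to a five- or seven-membered ring in this place, or to an amine or a hydroxyl group on the new ring.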